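The compounds below may be only part of what the source reports. "The series", "measured", "known", "first", "only" and "open" are said of these compounds alone.

Measured compounds:
- compound 1, `COc1ccc(CNc2nc([Se]C)nc3ccccc23)cc1`: 33000 nM
- compound 2, `COc1ccc(CNc2nc([SeH])nc3ccccc23)cc1`: 7110 nM
- compound 3, `CSc1nc(NCc2ccccc2)c2ccccc2n1`: 37900 nM

All three were tested in a functional assay on HTB-54 cells (Homo sapiens) for cytotoxicity, read by MTT assay, with a stated time of 72 h; on this read-out lower numbers stand for stronger inhibition of growth and higher numbers for weaker inhibition of growth. Compound 3 gives the highest number of the three. It sits close to compound 1, whose number is lower by an amount that stays within the scatter, and far from compound 2, whose number is lower by an amount beyond the scatter.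

Within the data shown here, the one single-place step that has been measured runs from compound 1 to compound 2: a 4.6-fold lower number from compound 1 to compound 2 (0.67 log units; beyond the scatter). It concerns the group on the selenium, not the benzyl ring.

Compound 4, `COc1ccc(CNc2nc(SC)nc3ccccc23)cc1`, is not yet measured. Its change from compound 3 is methoxy in place of hydrogen on an aromatic carbon. Among the measured compounds shown here, no measured step touches this change. Compound 1 and compound 3 differ in two places at once, one of them this methoxy, and their numbers lie within the scatter of each other, so they give no sign of a shift tied to the methoxy. The expectation is therefore no step beyond the scatter: a 1.1-fold lower number from compound 3 to compound 4 (0.03 log units; within the scatter). In this assay compound 4 is estimated at 35000 nM, within a range from 15000 nM to 80000 nM.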

Compound 4, concentration for 50% growth inhibition: 93700 nM
Beside the measured number, compound 4's estimate is 2.7-fold (0.43 log units) below it; the measured number lies above the stated range.
By their numbers in this assay, from the lowest: compound 2; then compounds 1 and 3 (each within the scatter of the next); then compound 4.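

In this assay the methoxy group, para to a large group, now has a step of its own: putting it in place of hydrogen gives a 2.5-fold higher number from compound 3 to compound 4 (0.39 log units; beyond the scatter) and so weakens growth inhibition, which shows that this place on the aromatic ring is not indifferent to change. Compound 4 also lets the selenium end be read with the methoxy held fixed: a methyl on sulfur in place of a methyl on selenium gives a 2.8-fold higher number from compound 1 to compound 4 (0.45 log units; beyond the scatter) as a modest step, while the same methyl on sulfur in place of the lone selenium atom gives a 13-fold higher number from compound 2 to compound 4 (1.12 log units; beyond the scatter) as a large one. Compound 4 therefore shows the weakest growth inhibition of the four, and sulfur in place of selenium weakens it in both of these pairs.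

As far as these compounds go, a hydroxyl or a fluorine at the methoxy's place, a longer chain in place of the methyl on sulfur, and the effect of removing the methoxy with selenium present all remain open. No supporting measurement bears on why these numbers move as they do.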